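A few compounds are considered here, and "the series" means these few. Any claim that something is new, unique, unknown or untested is made for them only; others in the source may bear on it.

Measured compounds in the series:

compound 1 `CC(=O)Oc1ccc(C(=O)Nc2cc3ccc(OCC4CCCN(C)C4)c(C)c3oc2=O)cc1CC=C(C)C` — 1650 nM
compound 2 `CC(=O)Oc1ccc(C(=O)Nc2cc3ccc(OCC4CCN(C)C4)c(C)c3oc2=O)cc1CC=C(C)C` — 1880 nM
compound 3 `CCNCCCOc1ccc2cc(NC(=O)c3ccc(O)c(CC=C(C)C)c3)c(=O)oc2c1C` — 980 nM

In a functional assay on MCF7 cells (Homo sapiens) for antiproliferative activity (on this read-out higher numbers stand for weaker inhibition and lower numbers for stronger inhibition), compound 3 gives the lowest of the three numbers, but its gap to compound 1 and its gap to compound 2 both lie within the usual scatter, so no ranking of the three is claimed. For the measured compounds named here, the only single-point step measured so far, a 1.1-fold higher number from compound 1 to compound 2 (0.06 log units; within the scatter), alters the amine-bearing substituent on the oxygen of the aromatic ring and sits within the scatter.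

The next compound, compound 4 `CC(C)=CCc1cc(C(=O)Nc2cc3ccc(OCCCNCC(N)=O)c(C)c3oc2=O)ccc1O`, differs from compound 3 in one place: carbamoyl in place of methyl on a saturated chain carbon bound to an amine nitrogen. The measured step from compound 1 to compound 2 touches a different part of that same substituent and does not repeat this exchange, so it offers only indirect guidance; its size suggests that changes in this region of the shared core have so far left the read-out unmoved. Going by the values given here, with no closer precedent, the step expected from compound 3 to compound 4, a 1.2-fold higher number from compound 3 to compound 4 (0.09 log units; within the scatter), is taken as small, in no firm direction. Compound 4 is therefore estimated at 1200 nM, with a range from 450 nM to 3200 nM.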

Compound 4, half-maximal inhibitory concentration: 1460 nM
The estimate for compound 4 lay 1.2-fold (0.09 log units) below the measured number, and the stated range covers the measured number.
By their numbers in this assay, from the lowest: compounds 3, 4, 1 and 2 (each within the scatter of the next).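

In this assay, carbamoyl in place of methyl on a saturated chain carbon bound to an amine nitrogen gives a 1.5-fold higher number from compound 3 to compound 4 (0.17 log units; within the scatter), so the two compounds cannot be told apart on this read-out. For the compounds shown here, this is the first measured exchange at this place; the earlier step concerned the 1-methylpiperidin-3-yl and 1-methylpyrrolidin-3-yl groups of compounds 1 and 2. Ethyl to carbamoylmethyl brings in one hydrogen-bond donor, one hydrogen-bond acceptor and two more heavy atoms, and compound 4 still stays within the scatter of compound 3, a single exchange from which no trend follows; no supporting data bear on this result.

Going by these compounds, whether a carboxylic acid, a primary amine or a longer chain at this place would give a step beyond the scatter remains open. Also open, on these data alone, is whether carbamoyl behaves alike on a compound carrying the acetate ester of compound 1.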